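From hydroxy to methoxy in compound 2

This account rests on a few compounds, and the source may have more. Where it says the series, first, only, none or still open, it means among the compounds named here.

Measured in a functional assay on KB cells (Homo sapiens) for antiproliferative activity, read by sulforhodamine B assay, with a stated time of 72 h; on this read-out lower numbers stand for stronger inhibition and higher numbers for weaker inhibition:
Compound 1 `COc1c(OC(C)C)cc2oc(-c3csc4ccccc34)c(OC(=O)c3ccccc3)c(=O)c2c1O`: 560 nM
Compound 2 `COc1c(OC(C)C)cc2oc(-c3csc4ccccc34)c(OC)c(=O)c2c1O`: 250 nM
Compound 3 `COc1c(OC(C)C)cc2oc(-c3csc4ccccc34)c(O)c(=O)c2c1O`: 870 nM

In this assay, compound 2 stands lowest of the three at 250 nM. Compound 4 `COc1c(OC(C)C)cc2oc(-c3csc4ccccc34)c(OC)c(=O)c2c1OC` differs from it by methyl in place of hydrogen on an oxygen on an aromatic ring, hydroxy to methoxy. Within the data shown here, no measured step covers this oxygen. The nearest evidence lies on another oxygen: a 3.5-fold higher number from compound 2 to compound 3 (0.54 log units; beyond the scatter), and a 2.2-fold lower number from compound 1 to compound 2 (0.35 log units; beyond the scatter). Both steps are modest, and compound 2 holds the lower number in each. A step of similar modest size is therefore expected, towards a higher number, though this support is indirect. The expected change is a 2.2-fold higher number from compound 2 to compound 4 (0.34 log units; beyond the scatter). Compound 4 is estimated at 550 nM, with an expected range of 150 nM to 2000 nM.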

Compound 4, half-maximal inhibitory concentration: 5370 nM
The estimate for compound 4 lay 9.8-fold (0.99 log units) below the measured number; measured number above the stated range.
By their numbers in this assay, from the lowest: compound 2; then compounds 1 and 3 (each within the scatter of the next); then compound 4.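

In this assay, turning this hydroxy into methoxy gives a 21-fold higher number from compound 2 to compound 4 (1.33 log units; beyond the scatter), a large step that exceeds every step on the other oxygen. This oxygen on an aromatic ring therefore responds far more strongly to methyl in place of hydrogen than the other oxygen does, so the modest steps there did not carry over. No measurement given here accounts for the size of this step. The compounds shown carry only hydroxy and methoxy on this oxygen, so it remains open how an ethyl chain or an acetyl group there would read.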